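This account rests on a few compounds, and the source may have more. Where it says the series, first, only, none or still open, it means among the compounds named here.

Compound 1 `COc1ccc(-c2nn(-c3ccccc3)cc2C(=O)NOCc2ccccc2F)cc1` gives 2900 nM in a functional assay on HeLa cells (Homo sapiens) for antiproliferative activity, read by MTT assay, with a stated time of 48 h, in the presence of a further agent that is not named here; a higher number here means a weaker inhibitor of growth, a lower number a stronger inhibitor of growth. Compound 2 `COc1ccc(-c2nn(-c3ccccc3)cc2C(=O)NOCc2ccccc2Cl)cc1` gives 3480 nM in this assay; the step of a 1.2-fold lower number from compound 2 to compound 1 (0.08 log units; within the scatter) belongs to the change (fluoro in place of chloro on an aromatic carbon). Compound 3 `O=C(NOCc1ccccc1)c1cn(-c2ccccc2)nc1-c1ccc(Cl)cc1` gives 8350 nM in this assay, the highest of the three numbers; the difference between the core of compound 3 and the core of compound 2 is not broken down here. Compound 4 `O=C(NOCc1ccccc1)c1cn(-c2ccccc2)nc1-c1ccc(F)cc1` is not yet measured in this assay. It differs from compound 3 by fluoro in place of chloro on an aromatic carbon, the same kind of change as that from compound 2 to compound 1, though here the place is para to a large group rather than ortho to a large group. A step of a 1.2-fold lower number from compound 3 to compound 4 (0.08 log units; within the scatter) is expected in this assay. This rests on compound 3 at 8350 nM and on the earlier step of a 1.2-fold lower number from compound 2 to compound 1 (0.08 log units; within the scatter), which lay within the scatter. Compound 4 is therefore estimated at 7000 nM, expected between 3500 nM and 14000 nM.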

Compound 4, concentration for 50% growth inhibition: 6110 nM
Estimate against measurement, compound 4: 1.1-fold (0.06 log units) above; low and high end bracket the measured number.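

In this assay, the exchange of 4-chlorophenyl for 4-fluorophenyl gives a 1.4-fold lower number from compound 3 to compound 4 (0.14 log units; within the scatter), and this step agrees with the earlier one on the other core: the same change on two cores in this assay, a 1.2-fold lower number (0.08 log units; within the scatter) from compound 2 to compound 1 and a 1.4-fold lower number (0.14 log units; within the scatter) from compound 3 to compound 4, 1.1-fold (0.06 log units) apart, within the scatter of two such steps The exchange of chloro for fluoro therefore carries across these two cores without a visible difference in this assay. Both steps lie within the scatter, so this shows neither a real gain from fluoro nor a rule for other cores in the series.

Still open, as far as these compounds go, is whether a group other than a halogen, such as an amine, a nitrile or a carboxylic acid, in place of the fluoro of compound 4 would move the number beyond the scatter. Also open, from the compounds shown here alone, is whether the agreement between cores extends to such groups.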